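The source may report more compounds than this note shows. Statements on the series, on what has been measured and on what is new or still open speak of the compounds shown alone.

The measured compounds:

Compound 1, `O=S(=O)(NCC1CCN(CCCc2c[nH]c3ccc(-n4cnnc4)cc23)CC1)c1ccccc1`: 73%
Compound 2, `OCCC(NC1CCN(CCCc2c[nH]c3ccc(-n4cnnc4)cc23)CC1)c1ccccc1`: 100%
Compound 3, `C[C@@H](NC1CCN(CCCc2c[nH]c3ccc(-n4cnnc4)cc23)CC1)c1ccccc1`: 90%

All three were tested in a functional assay on CHO cells for activation of 5-hydroxytryptamine receptor 1D (Homo sapiens), read by GTPgammaS binding; on this read-out higher numbers stand for larger maximal responses and lower numbers for smaller maximal responses. Compound 3 stands second highest of the three on that read-out. Its nearest neighbour is compound 2: the step of a number 10 percentage points lower from compound 2 to compound 3 (within the scatter) lies within the scatter, so the two compounds cannot be told apart. Compound 1 lies furthest away, and the step of a number 17 percentage points higher from compound 1 to compound 3 (beyond the scatter) is beyond the scatter, as is the step of a number 27 percentage points higher from compound 1 to compound 2 (beyond the scatter).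

The next compound is compound 4, `C[C@@H](NC1CCN(CCCc2c[nH]c3ccc(-n4ccnc4)cc23)CC1)c1ccccc1`. It differs from compound 3 only in the group on the aromatic ring of the shared core: 1H-imidazol-1-yl in place of 4H-1,2,4-triazol-4-yl on an aromatic carbon. Among the compounds with values here, none of the measured steps touches this part of the molecule; all of them concern the group on the saturated ring or the amine nitrogen. Within the data shown here, there is therefore no measured step that bears directly on the change from compound 3 to compound 4, and the expectation rests on the observation that the three measured values in this assay all lie in the upper range. Compound 4 is therefore expected to show a step of a number 5 percentage points lower from compound 3 to compound 4 (within the scatter), which stays within the scatter. The estimate for compound 4 in this assay is 85%, with a range from 65% to 100%.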

Compound 4, largest response reached (reported as efficacy), in percent of the reference or control that the assay uses: 65%
Estimate against measurement, compound 4: 20 percentage points above, and the stated range covers the measured number.
By their numbers in this assay, from the lowest: compounds 4 and 1 (each within the scatter of the next); then compounds 3 and 2 (each within the scatter of the next).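

In this assay, within the data shown here, the group on the aromatic carbon of the shared core proves to be a position that counts: the step of a number 25 percentage points lower from compound 3 to compound 4 (beyond the scatter) is the first measured change at this place, whereas the earlier steps all concerned the group on the saturated ring or the amine nitrogen. The change is small in its make-up, since both groups have 5 heavy atoms in one five-membered aromatic ring, and the entering 1H-imidazol-1-yl has 3 carbon and 2 nitrogen atoms where the leaving 4H-1,2,4-triazol-4-yl has 2 carbon and 3 nitrogen atoms. Nothing at hand explains why this exchange lowers the maximal response.

As far as these compounds go, the step rests on a single pair carrying the 1-phenylethyl group on the amine nitrogen, so it remains open whether the same exchange would lower the response with 3-hydroxy-1-phenylpropyl there or with the ((phenylsulfonyl)amino)methyl group on the saturated ring carbon. Also open, from the compounds shown here alone, is how other groups would fare at this aromatic carbon, such as a 1H-pyrazol-1-yl ring, a tetrazole ring or an open-chain amide.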